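Swapping a chain-end acid for a triazole on an acetophenone core

The source may hold more compounds than are shown below. What is called first, only, known or untested is meant among the compounds shown, and "the series" means these compounds.

Measured so far in an assay on isolated protein for binding affinity to leukotriene B4 receptor 1 (Homo sapiens), tested at 1 uM; a lower number here means less inhibition, a higher number more inhibition at the concentration tested (going by the name of the read-out):
compound 1 `C=CCc1cc(C(C)=O)c(O)cc1OCCCC#N` gives 6%
compound 2 `C=CCc1cc(C(C)=O)c(O)cc1OCCCCCCCCC#N` gives 50%
compound 3 `CCc1cc(C(C)=O)c(O)cc1OCCCCCC(C)(C)C(=O)O` gives 73%

Compound 3 stands highest of the three numbers in this assay, beyond the scatter above compound 2 and far above compound 1. Going by the values given here, the only step measured between neighbours, a number 44 percentage points higher from compound 1 to compound 2 (beyond the scatter), shows that stretching the chain that carries a nitrile raised inhibition by a large amount.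

Compound 4 `CCc1cc(C(C)=O)c(O)cc1OCCCCCn1cncn1` is the next structure. Compared with compound 3, the change is 1H-1,2,4-triazol-1-yl in place of 1-carboxy-1-methylethyl on a saturated chain carbon, five bonds along the chain from an oxygen on an aromatic ring. Among the compounds with values here, no measured pair shows this exchange; the one available step concerns chain length, not the end group, so it bears only indirectly, by indicating that compound 4 keeps a chain of a length comparable to that of compound 2 and compound 3. Since compound 2, which carries a neutral end group on a similar chain, gives 50%, the expected direction is downward from compound 3, with a step estimated as a number 28 percentage points lower from compound 3 to compound 4 (beyond the scatter). For compound 4 the estimate in this assay is 45%, expected to lie between 15% and 75%.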

Compound 4, a percentage reported as inhibition, at one concentration (the size of the read-out at that concentration, not a potency): 30%
Estimate against measurement, compound 4: 15 percentage points above; measured number inside the range.
By their numbers in this assay, from the lowest: compound 1; then compound 4; then compound 2; then compound 3.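

In this assay, the end group proves to matter in its own right: putting 1H-1,2,4-triazol-1-yl in place of 1-carboxy-1-methylethyl, on a saturated chain carbon five bonds along the chain from an oxygen on an aromatic ring, gives a number 43 percentage points lower from compound 3 to compound 4 (beyond the scatter). Going by these compounds alone, the earlier step concerned only chain length, so this is the first measured pair in which the end of the chain is exchanged, and the triazole does not match the group that carries the carboxylic acid, although compound 4 still reads 30%. The counted differences are plain, with the entering group having 0 hydrogen-bond donors and 3 acceptors against 1 of each in the leaving group, but no measurement here ties the fall to any of these differences.

As far as these compounds go, it remains open whether the higher number belongs to the carboxylic acid itself or also depends on the two methyl groups on the carbon that bears it, a question that a plain carboxylic acid without those methyl groups at the chain end could address. Also open, from the compounds shown here alone, are how a tetrazole or an amide would read at this place, and whether a longer chain would raise the number for the triazole as it did for the nitrile.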